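Aryl sulfonyl variation and Vero cell cytotoxicity limits

The compounds below may be only part of what the source reports. "The series", "measured", "known", "first", "only" and "open" are said of these compounds alone.

Compound 3 `CCCc1nc2c(C)cc(-c3nc4ccccc4n3C)cc2n1S(=O)(=O)c1c(C)cc(C)cc1C` carries a 2,4,6-trimethylphenyl on the sulfonyl sulfur. In an ADME assay on Vero cells (Chlorocebus sabaeus) for cytotoxicity, read by MTT assay (a higher number here means a weaker inhibitor, a lower number a stronger inhibitor), compound 3 gives only a limit, > 50000 nM. Compound 1 `CCCc1nc2c(C)cc(-c3nc4ccccc4n3C)cc2n1S(=O)(=O)c1ccccc1` likewise gives a limit in this assay, > 50000 nM. Compound 2 `CCCc1nc2c(C)cc(-c3nc4ccccc4n3C)cc2n1S(=O)(=O)c1ccc(C)cc1` also gives a limit in this assay, > 50000 nM. The steps a step that the two limits leave unreadable from compound 1 to compound 2, a step that the two limits leave unreadable from compound 1 to compound 3 and a step that the two limits leave unreadable from compound 2 to compound 3 stay unreadable, as the limit of > 50000 nM in this assay, at which 3 of the 3 values shown sit, shows. Compound 4 `CCCc1nc2c(C)cc(-c3nc4ccccc4n3C)cc2n1S(=O)(=O)c1ccc(OC)cc1` differs from compound 3 by 4-methoxyphenyl in place of 2,4,6-trimethylphenyl on a sulfonyl sulfur. Among the measured compounds shown here, no measured step covers a 4-methoxyphenyl on the sulfonyl sulfur; the three aryl sulfonyl variants all sit at the limit. For compound 4 the expected outcome in this assay is again a limit, estimated at 60000 nM, within 25000 nM to 150000 nM. The step that the limit leaves unreadable from compound 3 to compound 4 is expected to remain unreadable.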

Compound 4, half-maximal inhibitory concentration: > 50000 nM
Compound 4: only a limit was reported (the forecaster's own chance of this, stated with the estimate: 85%); the middle value does not contradict the limit.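

In this assay, compound 4 gives only a limit, as do compound 1, compound 2 and compound 3, so no step among them can be read: the limit of > 50000 nM in this assay, at which 4 of the 4 values shown sit.

The compounds shown leave open whether these aryl groups on the sulfonyl sulfur differ at all in this assay.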